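Piperidin-4-yl in place of oxan-4-yl on compound 2

The compounds below may be only part of what the source reports. "The series", "measured", "known", "first", "only" and "open" are said of these compounds alone.

Of the compounds shown here, two have numbers so far in a physicochemical assay for solubility, in phosphate buffer, at pH 7.4 (a lower number here means a less soluble compound, a higher number a more soluble compound), and they sit well apart. Compound 2 `COc1cc(C(=O)N2CCCC2)ccc1-c1ccnc2[nH]c(C3CCOCC3)cc12` gives 15000 nM and stands lowest of the two. Compound 1 `CC(C)n1cc(-c2ccnc3[nH]c(C4CCNCC4)cc23)ccc1=O` gives 910000 nM and the gap between them lies beyond the scatter. The two differ in more than one place, so that gap cannot be read as the effect of any single change.

Next comes compound 3 `COc1cc(C(=O)N2CCCC2)ccc1-c1ccnc2[nH]c(C3CCNCC3)cc12`, which matches compound 2 except in one group. The change is piperidin-4-yl in place of oxan-4-yl on an aromatic carbon and amounts to piperidin-4-yl in place of oxan-4-yl on an aromatic carbon, next to the ring nitrogen.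

For the measured compounds named here, no measured pair isolates this change. Going by the values given here, the only guide is compound 1 at 910000 nM as the one measured compound that also carries piperidin-4-yl, although the rest of its structure differs. An upward step beyond the scatter is therefore expected, and it is estimated as a 13-fold higher number from compound 2 to compound 3 (1.12 log units; beyond the scatter) in this assay for now. For compound 3 the estimated value is 200000 nM with an expected range from 50000 nM to 800000 nM at this stage.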

Compound 3, solubility: 590000 nM
Compound 3: the middle estimate sits 3.0-fold (0.47 log units) below what was measured; the range from low to high includes it.
By their numbers in this assay, from the lowest: compound 2; then compounds 3 and 1 (each within the scatter of the next).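

In this assay, for the compounds shown here, piperidin-4-yl in place of oxan-4-yl on an aromatic carbon, next to the ring nitrogen, gives a 39-fold higher number from compound 2 to compound 3 (1.59 log units; beyond the scatter) with nothing else in the structure altered, and this is the first single change that can be read. The position is therefore not silent in this assay: a large step follows even though the six-membered non-aromatic ring stays and the exchange is one of ring hetero atom, oxygen leaving and nitrogen entering, with a hydrogen-bond donor gained. No accompanying measurement explains the step, so the result records its size and direction only.

Going by these compounds, the step is known only on the shared structure of compound 2 and compound 3, so whether the same exchange carries the same size on another background remains open. Also open, on these data alone, is how this position responds to a piperidin-4-yl carrying a methyl on its nitrogen, to an open-chain amine or to a carboxylic acid, any of which would show whether the step follows the ring nitrogen itself or its hydrogen.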